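Cyano in Place of Chloro: Estimating Compound 4

The source may hold more compounds than are shown below. What is called first, only, known or untested is meant among the compounds shown, and "the series" means these compounds.

Of the compounds shown here, three have been measured in a functional assay on C6 cells (Rattus norvegicus) for cytotoxicity, read by MTT assay, with a stated time of 24 h, tested at 6 ug/mL; on this read-out lower numbers stand for a stronger effect and higher numbers for a weaker effect at the one concentration tested. Compound 1 `O=C(CSc1nnnn1-c1ccccc1)N/N=c1/scc(-c2ccccc2)n1-c1ccccc1` gives 52.1%, compound 2 `O=C(CSc1nnnn1-c1ccccc1)N/N=c1/scc(-c2ccc(Cl)cc2)n1-c1ccccc1` gives 77.4%, and compound 3 `O=C(CSc1ncccn1)N/N=c1/scc(-c2ccc(Cl)cc2)n1-c1ccccc1` gives 95.9%. Compound 2 thus stands second highest of the three: the step of a number 25.3 percentage points higher from compound 1 to compound 2 (beyond the scatter) leads up to it, and the step of a number 18.5 percentage points higher from compound 2 to compound 3 (beyond the scatter) leads on from it. Compound 4 `N#Cc1ccc(-c2cs/c(=N/NC(=O)CSc3nnnn3-c3ccccc3)n2-c2ccccc2)cc1` is not yet measured; it differs from compound 2 by cyano in place of chloro on an aromatic carbon. For the measured compounds named here, of the measured steps, only that from compound 1 to compound 2 touches the same aromatic carbon, and it was modest; nothing measured shows a cyano group. The expected step is therefore small, a number 9.4 percentage points lower from compound 2 to compound 4 (within the scatter). The estimate for compound 4 is 68%, within 45% to 92%.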

Compound 4, a percentage reported as activity, at one concentration (the size of the read-out at that concentration, not a potency): 78.8%
Estimate against measurement, compound 4: 10.8 percentage points below; the range from low to high includes it.
By their numbers in this assay, from the lowest: compound 1; then compounds 2 and 4 (each within the scatter of the next); then compound 3.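

Cyano in place of chloro gives a number 1.4 percentage points higher from compound 2 to compound 4 (within the scatter) in this assay, so at this ring carbon the two groups cannot be told apart by this read-out. Hydrogen at the same carbon does differ: cyano in place of hydrogen gives a number 26.7 percentage points higher from compound 1 to compound 4 (beyond the scatter). Nothing measured here offers a reason for this result. Still open, going by these compounds, is how an amine, a methoxy group or a carboxylic acid at this carbon would read. Also open, on these data alone, is whether pyrimidin-2-yl in place of 1-phenyl-1H-tetrazol-5-yl would act the same alongside cyano.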